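This account rests on a few compounds, and the source may have more. Where it says the series, first, only, none or still open, it means among the compounds named here.

Measured in a physicochemical assay for solubility, at pH 7.4; on this read-out lower numbers stand for lower solubility and higher numbers for higher solubility
- compound 1 `O=C(NCC1CCOCC1)c1cnc(Nc2cccc(Br)c2)cc1C1CC1` gives 45 ug/mL
- compound 2 `N#Cc1cccc(Nc2cc(C3CC3)c(C(=O)NCC3CCOCC3)cn2)c1` gives 4 ug/mL

Among the compounds with values here, compound 2 stands lowest of the two numbers at 4 ug/mL, and compound 1 is its only neighbour, beyond the scatter.

Next in line is compound 3 `Cc1cccc(Nc2cc(C3CC3)c(C(=O)NCC3CCOCC3)cn2)c1`, which has methyl in place of cyano on an aromatic carbon, meta to a large group (methyl in place of cyano on an aromatic carbon). This turns 3-cyanophenyl into 3-methylphenyl.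

Within the data shown here, the one measured step bearing on this change is an 11-fold lower number from compound 1 to compound 2 (1.05 log units; beyond the scatter), with cyano in place of bromo on an aromatic carbon. That step is large, and it shows that swapping the group at this place can move the number a long way. Among the measured compounds shown here, it says nothing directly about methyl, since no methyl compound has a number yet. With cyano leaving again, a rise is expected in this assay, probably beyond the scatter but smaller than the measured step.

The estimated step is a 4.5-fold higher number from compound 2 to compound 3 (0.65 log units; beyond the scatter).

For compound 3 the estimate is 18 ug/mL, with an expected range from 6 ug/mL to 60 ug/mL.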

Compound 3, solubility: 26 ug/mL
Compound 3: middle estimate off by 1.4-fold (0.16 log units), on the low side, and the stated range covers the measured number.
By their numbers in this assay, from the lowest: compound 2; then compounds 3 and 1 (each within the scatter of the next).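

In this assay, methyl in place of cyano on this aromatic carbon gives a 6.5-fold higher number from compound 2 to compound 3 (0.81 log units; beyond the scatter), so the large step seen earlier between bromo and cyano is not specific to bromo: a second group at the same place also stands well clear of cyano. Methyl in place of bromo gives a 1.7-fold lower number from compound 1 to compound 3 (0.24 log units; within the scatter), which leaves 3-methylphenyl and the bromo-bearing ring indistinguishable on this read-out, and among these three compounds only compound 2, with its 3-cyanophenyl, stands apart. Nothing available here bears on why the number moves with these swaps.

Three groups at one place cannot show whether the low number belongs to cyano alone or would also appear with other groups there, such as methoxy, an amine or a carboxylic acid. Within the data shown here, also open is whether the step between cyano and methyl would carry over with the same group on another carbon of that ring, or with a different amide chain in place of the one shared by these compounds.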